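Swapping a phenyl for an ester on the triazole ring

This account rests on a few compounds, and the source may have more. Where it says the series, first, only, none or still open, it means among the compounds named here.

Of the compounds shown here, three sharing one core have been measured in an ADME assay on PANC-1 cells (Homo sapiens) for cytotoxicity, read by sulforhodamine B assay, with a stated time of 48 h, tested at 10 uM; a higher number here means more inhibition at the concentration tested (going by the name of the read-out), a lower number less inhibition. Compound 1 `CCCCCCCc1cn(C(c2ccccc2)c2cc3cc(Br)ccc3nc2OC)nn1` gives 16.6%, compound 2 `COc1nc2ccc(Br)cc2cc1C(c1ccccc1)n1cc(-c2ccc(OC(F)(F)F)cc2)nn1` gives 11.7%, and compound 3 `COc1nc2ccc(Br)cc2cc1C(c1ccccc1)n1cc(-c2ccccc2)nn1` gives 30.1%. Compound 3 stands highest of the three: the step of a number 13.5 percentage points higher from compound 1 to compound 3 (beyond the scatter) and the step of a number 18.4 percentage points higher from compound 2 to compound 3 (beyond the scatter) both lie beyond the usual scatter, while the step of a number 4.9 percentage points lower from compound 1 to compound 2 (within the scatter) does not.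

Compound 4 `CCOC(=O)c1cn(C(c2ccccc2)c2cc3cc(Br)ccc3nc2OC)nn1` is not yet measured. It differs from compound 3 at the same ring position where compounds 1 and 2 differ from it: ethoxycarbonyl in place of phenyl on an aromatic carbon. The two measured steps that bear on this position are those from compound 1 and from compound 2 to compound 3, and both show that replacing the phenyl on that carbon by something else lowered inhibition by a modest amount. Ethoxycarbonyl is neither a chain nor a substituted ring, so no measured pair matches it exactly, and the direction is taken from the two pairs that exist.

On that basis a modest fall is expected for compound 4, with the step of a number 13.1 percentage points lower from compound 3 to compound 4 (beyond the scatter). Compound 4 is estimated to give 17%, within a range from 5% to 32%.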

Compound 4, a percentage reported as inhibition, at one concentration (the size of the read-out at that concentration, not a potency): 15.4%
Compound 4: the middle estimate sits 1.6 percentage points above what was measured; the range from low to high includes it.
By their numbers in this assay, from the lowest: compounds 2, 4 and 1 (each within the scatter of the next); then compound 3.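

With a number 14.7 percentage points lower from compound 3 to compound 4 (beyond the scatter) in this assay, a third and quite different replacement for the phenyl on this carbon of the five-membered aromatic ring joins the heptyl and 4-(trifluoromethoxy)phenyl groups: ethoxycarbonyl has no ring and brings hydrogen-bond acceptors that phenyl lacks. The other two new comparisons, a number 3.7 percentage points higher from compound 2 to compound 4 (within the scatter) and a number 1.2 percentage points lower from compound 1 to compound 4 (within the scatter), both stay within the usual scatter, so the ethoxycarbonyl, heptyl and 4-(trifluoromethoxy)phenyl compounds cannot be ranked against one another, and among these four compounds only the unsubstituted phenyl of compound 3 stands apart from the rest. Nothing available here explains why the plain phenyl stands apart from these three groups.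

As far as these compounds go, it remains open whether another group on this carbon could match or pass compound 3, such as a carboxylic acid, an amide, an amine, or a phenyl bearing a fluorine or methoxy group. A single-concentration reading also leaves open how these compounds would compare across a range of concentrations.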